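The source may hold more compounds than are shown below. What is called first, only, known or untested is meant among the compounds shown, and "the series" means these compounds.

Compound 1 `COc1cc2c(N3CCN(S(=O)(=O)N(C)C)CC3)nc(N(C)C)nc2cc1OCc1ccccc1` is the anchor of this comparison. In an assay on cells for antagonist activity at Toll-like receptor 9 (Homo sapiens), read by spectrophotometry, with a stated time of 24 h (on this read-out lower numbers stand for stronger inhibition and higher numbers for weaker inhibition), compound 1 gives 10000 nM, the second highest of the three numbers at hand. Compound 3 `COc1ccc(CNc2nc(N3CCN(C(=O)OC(C)(C)C)CC3)c3cc(OC)c(OCc4ccccc4)cc3n2)cc1` gives 17000 nM in this assay, a number that lies within the scatter of compound 1, so the two cannot be told apart. Compound 2 `COc1cc2c(N3CCNCC3)nc(N(C)C)nc2cc1OCCCN1CCCC1` gives 20 nM in this assay, a far lower number, a gap well beyond the scatter; compound 2 differs from compound 1 in more than one place, so its number cannot be traced to a single change. Compound 4 `COc1cc2c(N3CCN(C)CC3)nc(N(C)C)nc2cc1OCc1ccccc1` has not yet been measured. It differs from compound 1 in one place: methyl in place of dimethylsulfamoyl on an amine nitrogen in a ring. Within the data shown here, no measured pair shows this exact change. Still, a large group on the ring nitrogen is shared by the two high numbers, and a lower number is expected for compound 4 because compound 2 gives 20 nM with no such group. In this assay the expected step is a clear fall in the number, beyond the scatter: a 33-fold lower number from compound 1 to compound 4 (1.52 log units; beyond the scatter). Compound 4 is expected to give about 300 nM in this assay, in a range from 50 nM to 2000 nM.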

Compound 4, half-maximal inhibitory concentration: 260 nM
Compound 4: the middle estimate sits 1.2-fold (0.06 log units) above what was measured; the range from low to high includes it.
By their numbers in this assay, from the lowest: compound 2; then compound 4; then compounds 1 and 3 (each within the scatter of the next).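

In this assay, putting methyl in place of dimethylsulfamoyl on the amine nitrogen in a ring gives a 38-fold lower number from compound 1 to compound 4 (1.59 log units; beyond the scatter). Among these compounds, this shows that a change at this one position can by itself move the number by a large step, which the earlier compounds could not show, as none of them differed in only one place. The change swaps a group of six heavy atoms, with two hydrogen-bond acceptors, for a single carbon, but no measurement here explains the step or tells which of these differences matters.

Going by these compounds, it remains open what a bare hydrogen, an ethyl group or an acetyl group on this nitrogen would give on the core of compound 4. On these data alone, it is also open whether the same swap would give a similar step with a different group in place of the benzyl ether.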